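The source may hold more compounds than are shown below. What is called first, only, known or untested is meant among the compounds shown, and "the series" means these compounds.

Measured compounds in an assay for inhibition of serine/threonine-protein kinase PAK 4 (Homo sapiens), read by FRET and Z'-LYTE, with a stated time of 60 min, tested at 0.5 uM, in the presence of a further agent that is not named here; on this read-out higher numbers stand for a stronger effect at the one concentration tested and lower numbers for a weaker effect:
compound 1, `C[C@@H]1CN(C(=O)c2nc(Nc3cc(C4CC4)[nH]n3)c3cc(Cl)ccc3n2)CCN1C(=O)OC(C)(C)C`, gives 0.1%
compound 2, `C[C@@H]1CN(C(=O)c2nc(Nc3cc(C4CC4)[nH]n3)c3cc(Cl)ccc3n2)CCN1C(=O)OCc1ccccc1`, gives 4.4%
compound 3, `COC(=O)N1CCN(C(=O)c2nc(Nc3cc(C4CC4)[nH]n3)c3cc(Cl)ccc3n2)C[C@H]1C`, gives 73.9%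

Compound 3 stands highest of the three numbers. Its nearest neighbour is compound 2, lying beyond the scatter below it, and the furthest is compound 1, also beyond the scatter. The two steps onto compound 3 are both large: a number 73.8 percentage points higher from compound 1 to compound 3 (beyond the scatter), and a number 69.5 percentage points higher from compound 2 to compound 3 (beyond the scatter). Between the other two, a number 4.3 percentage points higher from compound 1 to compound 2 (within the scatter).

Compound 4, `C[C@@H]1CN(C(=O)c2nc(Nc3cc(C4CC4)[nH]n3)c3cc(Cl)ccc3n2)CCN1C(=O)OCOC(=O)C(C)(C)C`, has not been measured in this assay. It differs from compound 3 in one place: ((tert-butyl)carbonyl)oxy in place of hydrogen on a saturated chain carbon bound to an oxygen next to a carbonyl group. The two measured steps bear directly on this: each of them reached compound 3 by removing a larger group at an oxygen next to a carbonyl group, one step from tert-butyl to methyl and the other from phenyl to hydrogen on the saturated chain carbon, and each brought a large gain. Compound 4 reverses that direction, placing a seven-heavy-atom group on that same saturated chain carbon. A large downward step in this assay is therefore expected, a number 63.9 percentage points lower from compound 3 to compound 4 (beyond the scatter), landing near compound 1 and compound 2. Compound 4 is expected to give 10%, with a range from 0% to 45%.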

Compound 4, a percentage reported as inhibition, at one concentration (the size of the read-out at that concentration, not a potency): 0.7%
Beside the measured number, compound 4's estimate is 9.3 percentage points above it, within the range that was stated.
By their numbers in this assay, from the lowest: compounds 1, 4 and 2 (each within the scatter of the next); then compound 3.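

In this assay, the step of a number 73.2 percentage points lower from compound 3 to compound 4 (beyond the scatter) is large, and compound 4 carries ((tert-butyl)carbonyl)oxy in place of hydrogen on the saturated chain carbon bound to an oxygen next to a carbonyl group. The low read-out is no longer seen with tert-butyl or phenyl alone. The steps of a number 3.7 percentage points lower from compound 2 to compound 4 (within the scatter) and a number 0.6 percentage points higher from compound 1 to compound 4 (within the scatter) leave compound 1, compound 2 and compound 4 indistinguishable on this read-out, although ((tert-butyl)carbonyl)oxy has no ring and phenyl does; among these four compounds, only compound 3, with its methyl, stands apart from the rest. Nothing available bears on why this change has such a large effect.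

From the compounds shown here alone, with only methyl on that oxygen giving a high number, it remains open where between methyl and the three larger groups the fall sets in, which ethyl or isopropyl on that oxygen would help to locate. Going by these compounds, it also remains open whether a single small substituent on the saturated chain carbon, such as a hydroxyl, an amine or a fluorine atom, would keep the number of compound 3 or lose it.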